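Cap change on the piperidine nitrogen, compound 3 to compound 4

The source may hold more compounds than are shown below. What is called first, only, known or untested is meant among the compounds shown, and "the series" means these compounds.

Compound 3 `Cc1ccccc1C(=O)Nc1ccc(S(=O)(=O)NC2CCN(C(=O)CN)CC2)c2ccccc12` gives 4.1 nM in an assay on L1.2 cells for binding affinity to C-C chemokine receptor type 8 (Homo sapiens) (a lower number here means a stronger inhibitor, a higher number a weaker inhibitor), the lowest of the two numbers shown. Compound 1 `CCOC(=O)N1CCC(NS(=O)(=O)c2ccc(C(=O)NC3CCCCC3)c3ccccc23)CC1` gives 9.5 nM in this assay. Compound 2 `CCOC(=O)N1CCC(NS(=O)(=O)c2ccc(O)c3ccccc23)CC1` reaches only a limit of this assay, > 5000 nM, and not a number. Going by the values given here, the single measured step, an at least 520-fold higher number from compound 1 to compound 2 (2.72 log units; beyond the scatter), concerns the cyclohexylcarbamoyl and says nothing about the cap on the piperidine nitrogen; compounds 1 and 3 differ in more than one place, so their two values are read only side by side. Compound 4 `Cc1ccccc1C(=O)Nc1ccc(S(=O)(=O)NC2CCN(C(=O)N(C)C)CC2)c2ccccc12` carries dimethylamino in place of aminomethyl on a carbonyl carbon. Among the compounds with values here, no measured step bears on this change, so the expectation for compound 4 rests on compound 3 alone, with a step of a 1.5-fold higher number from compound 3 to compound 4 (0.17 log units; within the scatter) expected to stay within the scatter. For compound 4 in this assay an estimate of 6 nM is expected, between 2 nM and 20 nM.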

Compound 4, inhibition constant: 1.6 nM
Compound 4: middle estimate off by 3.8-fold (0.57 log units), on the high side; measured number outside the range, below it.
By their numbers in this assay, from the lowest: compound 4; then compound 3; then compound 1. At a limit, above all of these: compound 2.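

On the carbonyl carbon whose other neighbour is the amide-type nitrogen in a ring, dimethylamino in place of aminomethyl gives a 2.6-fold lower number from compound 3 to compound 4 (0.41 log units; beyond the scatter) in this assay. Going by these compounds alone, this is the first measured step at this position, and it shows that a group with 0 hydrogen-bond donors and 0 hydrogen-bond acceptors can replace aminomethyl here without any loss. Nothing at hand gives a cause for this step.

Still open, on these data alone, is whether diethylamino, a longer chain or a carboxylic acid on this carbonyl carbon would hold the low number of compound 4. Also open, as far as these compounds go, is whether the step carries over to the cyclohexylcarbamoyl series of compound 1.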